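Phenoxy in Place of Benzyl on the Aryl Amide

A few compounds are considered here, and "the series" means these few. Any claim that something is new, unique, unknown or untested is made for them only; others in the source may bear on it.

Compound 1 `C[C@H](NC(=O)C(=O)Nc1ccccc1)C(=O)N[C@@H](CC(=O)O)C(=O)COc1c(F)c(F)cc(F)c1F`: 670 nM
Compound 2 `C[C@H](NC(=O)C(=O)Nc1ccccc1-c1ccc[nH]1)C(=O)N[C@@H](CC(=O)O)C(=O)COc1c(F)c(F)cc(F)c1F`: 56 nM
Compound 3 `C[C@H](NC(=O)C(=O)Nc1ccccc1Cc1ccccc1)C(=O)N[C@@H](CC(=O)O)C(=O)COc1c(F)c(F)cc(F)c1F`: 10 nM

In a functional assay on Jurkat cells (Homo sapiens) for inhibition (on this read-out lower numbers stand for stronger inhibition and higher numbers for weaker inhibition), compound 3 stands at the lowest number of the three measured compounds. Its nearest neighbour is compound 2, separated by the step of a 5.6-fold lower number from compound 2 to compound 3 (0.75 log units; beyond the scatter), and its furthest is compound 1, separated by a 67-fold lower number from compound 1 to compound 3 (1.83 log units; beyond the scatter).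

Compound 4 `C[C@H](NC(=O)C(=O)Nc1ccccc1Oc1ccccc1)C(=O)N[C@@H](CC(=O)O)C(=O)COc1c(F)c(F)cc(F)c1F` differs from compound 3 in a single place: phenoxy in place of benzyl on an aromatic carbon. Among the compounds with values here, three measured steps bear on this position. The steps of a 12-fold lower number from compound 1 to compound 2 (1.08 log units; beyond the scatter) and a 67-fold lower number from compound 1 to compound 3 (1.83 log units; beyond the scatter) show that placing a ring-bearing group on that aromatic carbon instead of hydrogen brings a large fall in the number, while a 5.6-fold lower number from compound 2 to compound 3 (0.75 log units; beyond the scatter) shows that the choice between two such groups shifts the number only modestly. Within the data shown here, no measured step swaps one ring-bearing group for another of the same count of heavy atoms, so the effect of the oxygen-linked phenyl is inferred rather than known. The expectation is a modest step, a 2.0-fold higher number from compound 3 to compound 4 (0.30 log units; within the scatter), toward a somewhat higher number, since compound 3 already sits at the low end. The estimate for compound 4 in this assay is 20 nM, within a range from 5 nM to 80 nM.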

Compound 4, half-maximal inhibitory concentration: 530 nM
The estimate for compound 4 lay 27-fold (1.42 log units) below the measured number; measured number outside the range, above it.
By their numbers in this assay, from the lowest: compound 3; then compound 2; then compounds 4 and 1 (each within the scatter of the next).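

In this assay, a ring-bearing group on this aromatic carbon does not by itself bring the low number. Benzyl and phenoxy have the same count of heavy atoms and each has one six-membered aromatic ring, yet the exchange of the carbon link for an oxygen link gives a 53-fold higher number from compound 3 to compound 4 (1.72 log units; beyond the scatter). Phenoxy also shows no gain over hydrogen that can be told from the scatter, with a 1.3-fold lower number from compound 1 to compound 4 (0.10 log units; within the scatter), and it compares poorly with 1H-pyrrol-2-yl, with a 9.5-fold higher number from compound 2 to compound 4 (0.98 log units; beyond the scatter); nothing available here accounts for this difference between the two links.

The compounds shown leave open whether this large step belongs to oxygen alone or would also come with another link, such as an amine nitrogen or a sulfur atom joining the phenyl ring to the aromatic carbon. They also leave open whether a longer chain such as 2-phenylethyl, or a fluorine or a methoxy group on the outer ring of benzyl, would keep a number close to that of compound 3 at 10 nM.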